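A few compounds are considered here, and "the series" means these few. Any claim that something is new, unique, unknown or untested is made for them only; others in the source may bear on it.

Three compounds share one core and differ only in the aryl group on the amino nitrogen. Compound 1 `C=CC(=O)Nc1cccc(NC(=O)CSc2nc(Nc3ccccc3F)c3ccccc3n2)c1` gives 18700 nM in a functional assay on MDA-MB-231 cells (Homo sapiens) for inhibition, read by MTT assay, with a stated time of 72 h; a lower number here means a stronger inhibitor, a higher number a weaker inhibitor. Compound 2 `C=CC(=O)Nc1cccc(NC(=O)CSc2nc(Nc3ccccc3Br)c3ccccc3n2)c1` gives 15200 nM in this assay, and the two are separated by a 1.2-fold lower number from compound 1 to compound 2 (0.09 log units; within the scatter). Compound 3 `C=CC(=O)Nc1cccc(NC(=O)CSc2nc(Nc3cccc(F)c3)c3ccccc3n2)c1` gives 8160 nM in this assay; it is set apart from compound 1 by a 2.3-fold lower number from compound 1 to compound 3 (0.36 log units; beyond the scatter), while compound 2 sits within the scatter of it, as a 1.9-fold lower number from compound 2 to compound 3 (0.27 log units; within the scatter) shows. Compound 3 is thus the reference point with the smallest number in hand, though not separable from compound 2.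

Compound 4 `C=CC(=O)Nc1cccc(NC(=O)CSc2nc(Nc3cccc(Cl)c3)c3ccccc3n2)c1` is compound 3 with one alteration: chloro in place of fluoro on an aromatic carbon. Within the data shown here, the only measured step that bears on it is the halogen exchange from compound 1 to compound 2, where bromo replaced fluoro on the same aromatic ring and the result was a 1.2-fold lower number from compound 1 to compound 2 (0.09 log units; within the scatter), a change within the scatter. Among the measured compounds shown here, no step among the measured compounds shows a halogen swap moving the number beyond the scatter. Compound 4 is therefore expected to stay close to compound 3, with a step of a 1.2-fold lower number from compound 3 to compound 4 (0.07 log units; within the scatter) in this assay. The estimate for compound 4 is 7000 nM, expected to fall between 3500 nM and 14000 nM.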

Compound 4, half-maximal inhibitory concentration: 16300 nM
Beside the measured number, compound 4's estimate is 2.3-fold (0.37 log units) below it; measured number above the stated range.
By their numbers in this assay, from the lowest: compounds 3, 2, 4 and 1 (each within the scatter of the next, the first and the last beyond it).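

In this assay the change from 3-fluorophenyl to 3-chlorophenyl gives a 2.0-fold higher number from compound 3 to compound 4 (0.30 log units; within the scatter) and thus adds a second halogen exchange that stays within the scatter, this time on the ring position meta to a large group. The earlier compounds shown here left open whether a halogen at this place would set a compound apart from the 2-fluorophenyl compound, and the new steps answer that in the negative for chloro: the 3-chlorophenyl group gives a 1.1-fold higher number from compound 2 to compound 4 (0.03 log units; within the scatter) and a 1.1-fold lower number from compound 1 to compound 4 (0.06 log units; within the scatter) so that compound 3 alone, with fluoro, stands apart from compound 1, and placing a halogen here does not by itself produce that separation. No measurement shown here bears on the reason for these numbers.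

The compounds shown leave open whether a group other than a halogen at this place, such as a methoxy group, an amine or a carboxylic acid, would move the number beyond the scatter of compound 3 in this assay at all. They also leave open how a phenyl ring with no substituent would compare with these halogenated rings.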